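Compound 1 and a hydroxy group on its phenyl

This account rests on a few compounds, and the source may have more. Where it says the series, first, only, none or still open, it means among the compounds named here.

Within the data shown here, in a functional assay on HT-29 cells (Homo sapiens) for antiproliferative activity, read by MTT assay, with a stated time of 48 h (a higher number here means a weaker inhibitor of growth, a lower number a stronger inhibitor of growth), compound 1 `COC(=O)N1N=C(c2ccccc2)CC1c1cc(OC)c(OC)c(OC)c1` gives 6260 nM and is the only compound so far with an actual number. Compound 2 `COc1cc(C2CC(c3ccccc3)=NN2C(=O)OCc2ccccc2)cc(OC)c1OC` returns > 10000 nM as its result, which is a limit of the assay and not a number. Compound 3 `COC(=O)N1N=C(c2cccc(O)c2)CC1c1cc(OC)c(OC)c(OC)c1` keeps the core of compound 1 and carries one change, phenyl to 3-hydroxyphenyl hydroxy in place of hydrogen on an aromatic carbon in which hydroxy stands in place of hydrogen on an aromatic carbon. Among the measured compounds shown here, the only measured step is an at least 1.5-fold higher number from compound 1 to compound 2 (0.20 log units; that floor lies within the scatter) and it lies elsewhere in the molecule, so it says nothing direct about this change. No measured result points to a direction in this assay and no step beyond the scatter is expected. The expected step is a 1.4-fold lower number from compound 1 to compound 3 (0.14 log units; within the scatter) on this estimate. For compound 3 the estimated value is 4500 nM with an expected range from 1200 nM to 10000 nM for this measurement.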

Compound 3, concentration for 50% growth inhibition: 1350 nM
Beside the measured number, compound 3's estimate is 3.3-fold (0.52 log units) above it, within the range that was stated.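

In this assay, among these compounds, putting hydroxy in place of hydrogen on an aromatic carbon of the phenyl gives a 4.6-fold lower number from compound 1 to compound 3 (0.67 log units; beyond the scatter), the first step that clearly exceeds the scatter. Compound 3 is therefore a stronger inhibitor of growth than compound 1, which shows that this phenyl is a place where adding a single heavy atom can change the result. Nothing shown here explains why this step occurs.

From the compounds shown here alone, it remains open whether the gain depends on the hydroxy group itself, which a methoxy group, an amine or a fluorine atom at the same place would help to test. It is also open whether the gain depends on this place, since hydroxy appears at only one position on the phenyl in the compounds shown.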